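The source may hold more compounds than are shown below. What is called first, only, known or untested is meant among the compounds shown, and "the series" means these compounds.

Working notes on the series. Compound 1 `Cc1nn(-c2nc(-c3ccc(Cl)c(Cl)c3)c(SC(C)C)s2)c(C(=O)O)c1-c1ccc(Cl)cc1` gives 2500 nM in a functional assay on BJAB cells (Homo sapiens) for antiproliferative activity, with a stated time of 4 days; a higher number here means that more compound is needed for the effect, a lower number that less compound is needed. Compound 2 `COc1ccccc1-c1c(C)nn(-c2nc(-c3ccc(Cl)c(Cl)c3)c(SC(C)C)s2)c1C(=O)O` gives 14700 nM in this assay, and compound 3 `Cc1nn(-c2nc(-c3ccc(Cl)c(Cl)c3)c(SC(C)C)s2)c(C(=O)O)c1-c1cccc(Cl)c1` gives 13600 nM in this assay. Compound 3 thus stands second highest of the three measured numbers: compound 2 lies within the scatter of it, a 1.1-fold lower number from compound 2 to compound 3 (0.03 log units; within the scatter), while compound 1 is clearly separated, a 5.4-fold higher number from compound 1 to compound 3 (0.74 log units; beyond the scatter). The other measured step, a 5.9-fold higher number from compound 1 to compound 2 (0.77 log units; beyond the scatter), is of the same modest size.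

Compound 4 `Cc1nn(-c2nc(-c3ccc(Cl)c(Cl)c3)c(SC(C)C)s2)c(C(=O)O)c1-c1ccccc1C(F)(F)F` differs from compound 3 by 2-(trifluoromethyl)phenyl in place of 3-chlorophenyl on an aromatic carbon. For the measured compounds named here, the steps that bear on this are the three aryl exchanges: leaving 4-chlorophenyl cost a modest step in both directions tried, whereas exchanging one non-4-chloro aryl for another gave nothing beyond the scatter. Compound 4 is again a non-4-chloro aryl, so the expected step in this assay is none beyond the scatter, in either direction. Compound 4 is therefore expected to give 13000 nM, with a range from 4500 nM to 40000 nM. The estimated step is a 1.0-fold lower number from compound 3 to compound 4 (0.02 log units; within the scatter).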

Compound 4, half-maximal effective concentration: 5200 nM
Estimate against measurement, compound 4: 2.5-fold (0.40 log units) above; low and high end bracket the measured number.
By their numbers in this assay, from the lowest: compound 1; then compound 4; then compounds 3 and 2 (each within the scatter of the next).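

In this assay, the aryl groups other than 4-chlorophenyl do not all fall together at this position: 2-(trifluoromethyl)phenyl separates from 3-chlorophenyl, a 2.6-fold lower number from compound 3 to compound 4 (0.42 log units; beyond the scatter), and trifluoromethyl separates from methoxy on the same phenyl, a 2.8-fold lower number from compound 2 to compound 4 (0.45 log units; beyond the scatter). 4-Chlorophenyl still gives the lowest number of the four, a 2.1-fold higher number from compound 1 to compound 4 (0.32 log units; beyond the scatter), so the exchange at this position now gives an order of three levels rather than two. No measurement at hand bears on the reason for this order.

The substituent and its place on the phenyl ring remain entangled, as chlorine appears only in 3-chlorophenyl and 4-chlorophenyl, and trifluoromethyl only in 2-(trifluoromethyl)phenyl. Where 2-chlorophenyl, 4-(trifluoromethyl)phenyl or an unsubstituted phenyl would stand in this order remains open.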